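The source may hold more compounds than are shown below. What is called first, only, known or untested is meant among the compounds shown, and "the series" means these compounds.

Compound 1, `C=CCOCC(N)C(=O)NCc1ccccc1`: in a functional assay on the whole organism (strain NMRI) for inhibition, with Mus musculus as the target, in the formalin test, with a stated time of 30 min (a lower number here means that less compound is needed, a higher number that more compound is needed for the effect), compound 1 gives 75 mg/kg.
Compound 2, `CCC(C)C(N)C(=O)NCc1ccccc1`: in this assay compound 2 gives only a limit, > 22 mg/kg.
Compound 3, `N[C@H](CCO)C(=O)NCc1ccccc1`: in this assay compound 3 gives only a limit, > 67 mg/kg.

Compound 2 therefore stands on a limit and not on a number in this assay; of the three values shown, one other is a limit as well (the limit of > 67 mg/kg in this assay, at which 1 of the 3 values shown sits), so that its place among the three cannot be fixed. The piece follows the change to compound 4, `C#CCOCC(N)C(=O)NCc1ccccc1`, which differs from compound 2 by (propargyloxy)methyl in place of sec-butyl on a saturated chain carbon bound to an amine nitrogen and a carbonyl carbon. Among the compounds with values here, only one measured step touches this place: a step that the limit leaves unreadable from compound 1 to compound 2, and that step is unreadable because of the limit of > 22 mg/kg in this assay, at which 1 of the 3 values shown sits. So the size of the step from compound 2 to compound 4 in this assay cannot be read from the measured pairs, and its direction is open. What remains is that compound 1 carries the (allyloxy)methyl group at the same place and gives 75 mg/kg. Compound 4 is expected to land near that value, so the step that the limit leaves unreadable from compound 2 to compound 4 is an expectation only. Compound 4 is estimated at 60 mg/kg, with a range from 22 mg/kg to 160 mg/kg.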

Compound 4, dose for half-maximal effect: 74 mg/kg
Compound 4: middle estimate off by 1.2-fold (0.09 log units), on the low side; measured number inside the range.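

In this assay, ethynyl in place of vinyl on a saturated chain carbon bound to an oxygen on a saturated carbon gives a 1.0-fold lower number from compound 1 to compound 4 (0.01 log units; within the scatter), so the two side chains cannot be told apart in this assay. Within the data shown here, this is the first readable comparison at this position, since the earlier compounds offered only one number there. Both compounds with a number, compound 1 and compound 4, carry an ether oxygen in the side chain, but two compounds are too few to make this a pattern.

From the compounds shown here alone, the step from compound 2 to compound 4 cannot be read, because compound 2 gives only a limit, so the comparison between the sec-butyl group and the (propargyloxy)methyl group stays open: the limit of > 22 mg/kg in this assay, at which 1 of the 4 values shown sits. It also remains open whether a longer chain on the ether oxygen, or an amine at the end of that chain, would leave the dose in this assay where compound 1 and compound 4 stand or would shift it.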